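The source may hold more compounds than are shown below. What is called first, only, known or untested is meant among the compounds shown, and "the series" means these compounds.

Measured so far in an assay on isolated protein for inhibition of Amine oxidase [flavin-containing] A (Homo sapiens), read by fluorescence, with a stated time of 15 min; a lower number here means a stronger inhibitor, a higher number a weaker inhibitor:
compound 1 `COc1ccc(/C=C/c2cc(OC)cc(OC)c2/C=C/C(=O)c2cc3ccccc3oc2=O)cc1` — compound 1 gives 41700 nM
compound 2 `COc1ccc(/C=C/c2cc(OC)cc(OC)c2/C=C/C(=O)c2cc3ccc(C)cc3oc2=O)cc1` — compound 2 gives 58200 nM
compound 3 `COc1ccc(/C=C/c2cc(OC)cc(OC)c2/C=C/C(=O)c2cc3cc(Br)ccc3oc2=O)cc1` — compound 3 gives 12100 nM

Compound 3 holds the lowest of the three numbers, set apart by a 3.4-fold lower number from compound 1 to compound 3 (0.54 log units; beyond the scatter) and by a 4.8-fold lower number from compound 2 to compound 3 (0.68 log units; beyond the scatter). Compound 4 `COc1ccc(/C=C/c2cc(OC)cc(OC)c2/C=C/C(=O)c2cc3cc(Cl)ccc3oc2=O)cc1` differs from compound 3 by chloro in place of bromo on an aromatic carbon. Among the compounds with values here, no measured step exchanges one halogen for another; the only step at this place is a 3.4-fold lower number from compound 1 to compound 3 (0.54 log units; beyond the scatter), where bromo entered in place of hydrogen, while a 1.4-fold higher number from compound 1 to compound 2 (0.14 log units; within the scatter), methyl in place of hydrogen on an aromatic carbon, stayed within the scatter. Compound 4 is therefore expected to stay close to compound 3, with a 1.3-fold higher number from compound 3 to compound 4 (0.12 log units; within the scatter) in this assay, not beyond the scatter. The estimate for compound 4 is 16000 nM, ranging from 7000 nM to 36000 nM.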

Compound 4, half-maximal inhibitory concentration: > 60000 nM
Compound 4: only a limit was reported; the forecaster's own chance of this, stated with the estimate: 5%; middle value at least 3.7-fold (0.57 log units) from the limit.
By their numbers in this assay, from the lowest: compound 3; then compounds 1 and 2 (each within the scatter of the next). At a limit, above all of these: compound 4.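

In this assay, the identity of the halogen at this place matters: chloro in place of bromo gives an at least 4.9-fold higher number from compound 3 to compound 4 (0.69 log units; beyond the scatter), so the lower number seen with bromo does not carry over to chloro. The other two steps are an at least 1.4-fold higher number from compound 1 to compound 4 (0.15 log units; that floor lies within the scatter) and an at least 1.0-fold higher number from compound 2 to compound 4 (0.01 log units; that floor lies within the scatter), so neither supports an order. Compound 4 is reported only as a limit: the limit of > 60000 nM in this assay, at which 1 of the 4 values shown sits.

Going by these compounds, how far above that limit compound 4 truly lies stays open. So does whether iodo or fluoro at this place would track with bromo or with chloro.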